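Swapping Thiophene for a Phenol on a Shared Core

The source may hold more compounds than are shown below. What is called first, only, known or untested is meant among the compounds shown, and "the series" means these compounds.

Compound 2 `CC(Oc1ccccc1-c1cccs1)C1=NCCN1` is one of two compounds tested in an assay on CHO cells for displacement of a labelled ligand from Alpha-2B adrenergic receptor (Homo sapiens); on this read-out lower numbers stand for stronger inhibition and higher numbers for weaker inhibition; in this assay compound 2 gives 214 nM, the lowest of the two numbers. Among the measured compounds shown here, its only neighbour, compound 1 `CC(Oc1ccccc1-c1cccnc1)C1=NCCN1`, gives 933 nM in this assay, and the step of a 4.4-fold lower number from compound 1 to compound 2 (0.64 log units; beyond the scatter) shows that exchanging the aromatic group attached to the shared core moves the number by a clear margin. Compound 3 `CC(Oc1ccccc1-c1ccc(O)cc1)C1=NCCN1` changes that same group again: 4-hydroxyphenyl in place of thiophen-2-yl on an aromatic carbon. For the measured compounds named here, the one measured step that bears on this change is a 4.4-fold lower number from compound 1 to compound 2 (0.64 log units; beyond the scatter), where a six-membered ring bearing a hetero atom gave the higher number and the thiophene the lower one. Since the 4-hydroxyphenyl is again a six-membered ring, now carrying a hydrogen-bond donor, the step of a 2.1-fold higher number from compound 2 to compound 3 (0.32 log units; beyond the scatter) in this assay is expected to be a modest rise, though with wide uncertainty. For compound 3 the estimate in this assay is 450 nM, with a range from 120 nM to 1700 nM.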

Compound 3, inhibition constant: 813 nM
For compound 3 the middle estimate is 1.8-fold (0.26 log units) below the measured one; the range from low to high includes it.
By their numbers in this assay, from the lowest: compound 2; then compounds 3 and 1 (each within the scatter of the next).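

In this assay, a 3.8-fold higher number from compound 2 to compound 3 (0.58 log units; beyond the scatter) shows that the lower number of compound 2 does not carry over to this second six-membered ring, even though it bears a different substituent from the pyridin-3-yl group. The a 1.1-fold lower number from compound 1 to compound 3 (0.06 log units; within the scatter) lies within the scatter, so pyridin-3-yl and 4-hydroxyphenyl cannot be told apart at this position, and among these three compounds only the one with thiophen-2-yl stands apart, with no compound going against that split. Nothing shown here explains why the thiophen-2-yl compound differs.

On these data alone, whether the lower number belongs to five-membered rings in general or to thiophen-2-yl alone stays open, and furan-2-yl would bear on that. A plain phenyl group would help separate the contribution of the six-membered carbon ring from that of its hydroxyl group.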